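Shortening the amide chain from compound 2 to compound 3

The source may report more compounds than this note shows. Statements on the series, on what has been measured and on what is new or still open speak of the compounds shown alone.

Two compounds have been measured:
Compound 1, `C=CCCCCCCCCC(=O)Nc1cc2c(cc1F)c(=O)c(C(=O)OCC)cn2CC`: 87300 nM
Compound 2, `CCCCCCCCCCCCCCCC(=O)Nc1cc2c(cc1F)c(=O)c(C(=O)OCC)cn2CC`: 25200 nM

Both carry the same core, an amide on the ring with a long saturated or terminally unsaturated chain, and the measured read-out is a functional assay on DU-145 cells (Homo sapiens) for cytotoxicity, read by MTT assay; a higher number here means a weaker inhibitor, a lower number a stronger inhibitor. Among the measured compounds shown here, compound 2 stands at the lower of the two numbers, and the only step, a 3.5-fold lower number from compound 1 to compound 2 (0.54 log units; beyond the scatter), comes from a longer chain, heptyl in place of vinyl on a saturated chain carbon, eight bonds along the chain from a carbonyl carbon.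

Compound 3, `CCCCCCCCCCCC(=O)Nc1cc2c(cc1F)c(=O)c(C(=O)OCC)cn2CC`, is the next compound to be measured. Its change from compound 2 is hydrogen in place of butyl on a saturated chain carbon, ten or more bonds along the chain from a carbonyl carbon. For the measured compounds named here, this is the reverse of the direction taken in the single step known, since compound 3 carries a shorter chain than compound 2 but a longer one than compound 1. On that basis the number for compound 3 is expected to rise, the step of a 2.0-fold higher number from compound 2 to compound 3 (0.30 log units; within the scatter) falling short of the whole distance back to compound 1. For compound 3 the estimate is 50000 nM, with a range from 25000 nM to 110000 nM.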

Compound 3, half-maximal inhibitory concentration in the DU-145 assay: 12100 nM
The estimate for compound 3 lay 4.1-fold (0.62 log units) above the measured number; measured number below the stated range.
By their numbers in the DU-145 assay, from the lowest: compound 3; then compound 2; then compound 1.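

Among the saturated chains, the earlier step alone made a longer chain look favourable, but in the DU-145 assay hydrogen in place of butyl gives a 2.1-fold lower number from compound 2 to compound 3 (0.32 log units; beyond the scatter), so at this place on the chain the shorter chain of compound 3 gives the lower number. Also in the DU-145 assay, propyl in place of vinyl gives a 7.2-fold lower number from compound 1 to compound 3 (0.86 log units; beyond the scatter), which places compound 3 lowest of the three and shows that the number does not simply fall as the chain grows, with compound 2 going against that reading. In a physicochemical assay (a higher number here means that more compound is needed for the effect, a lower number that less compound is needed), compound 2 gives "not active" (no number reported) and compound 3 gives "not active" (no number reported), so the steps in that assay cannot be read.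

No measurement shown here explains why the numbers move in this way.

The compounds shown leave open whether the number in the DU-145 assay keeps falling with a still shorter chain, such as hexyl, or turns upward again. They also leave open what a terminal amine or carboxylic acid on the chain would do.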